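This account rests on a few compounds, and the source may have more. Where it says the series, first, only, none or still open, it means among the compounds named here.

Compound 1 `Fc1ccc(CSc2nnc(-c3ccncc3)n2-c2ccccc2)cc1`: 21100 nM
Compound 2 `Clc1ccc(CSc2nnc(-c3ccncc3)n2-c2ccccc2)cc1`: 13300 nM
Compound 3 `Fc1ccc(CSc2nnc(-c3ccncc3)n2-c2ccccc2)c(F)c1`: 14100 nM

These numbers come from a functional assay on MCF7 cells (Homo sapiens) for inhibition, read by MTT assay, with a stated time of 48 h; a higher number here means a weaker inhibitor, a lower number a stronger inhibitor. Compound 3 sits close to both companions: its number lies within the scatter of compound 2 and of compound 1. Compound 4 `O=[N+]([O-])c1ccccc1CSc1nnc(-c2ccncc2)n1-c1ccccc1` carries 2-nitrophenyl in place of 2,4-difluorophenyl on a saturated chain carbon bound to a sulfur. The steps already measured all concern the group on a saturated chain carbon bound to a sulfur: a 1.1-fold higher number from compound 2 to compound 3 (0.03 log units; within the scatter), a 1.6-fold lower number from compound 1 to compound 2 (0.20 log units; within the scatter) and a 1.5-fold lower number from compound 1 to compound 3 (0.18 log units; within the scatter). None of them moved the number beyond the scatter, so putting the 2-nitrophenyl group in place is expected to leave this assay little changed, and the step of a 1.0-fold lower number from compound 3 to compound 4 (0.00 log units; within the scatter) is expected to stay within the scatter. Compound 4 is therefore estimated at 14000 nM, with a range from 5000 nM to 40000 nM.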

Compound 4, half-maximal inhibitory concentration: > 50000 nM
Compound 4 gave a limit, no number; the forecaster's own chance of this, stated with the estimate: 5%; middle value at least 3.5-fold (0.55 log units) from the limit.
By their numbers in this assay, from the lowest: compounds 2, 3 and 1 (each within the scatter of the next). At a limit, above all of these: compound 4.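

The 2-nitrophenyl group moves the number beyond the scatter in all three steps in this assay: an at least 3.5-fold higher number from compound 3 to compound 4 (0.54 log units; beyond the scatter), an at least 3.7-fold higher number from compound 2 to compound 4 (0.57 log units; beyond the scatter) and an at least 2.3-fold higher number from compound 1 to compound 4 (0.37 log units; beyond the scatter). Compound 4 reads only as a limit of the assay, not a number: the limit of > 50000 nM in this assay, at which 1 of the 4 values shown sits. So the group on a saturated chain carbon bound to a sulfur can matter here, which the fluoro and chloro phenyl groups alone did not show.

Going by these compounds, how large these steps truly are stays open. Also open, on these data alone, is whether a 4-nitrophenyl or 2-aminophenyl group would behave like the 2-nitrophenyl group.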